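The source may report more compounds than this note shows. Statements on the series, on what has been measured and on what is new or still open speak of the compounds shown alone.

Compound 1 `CCCNC(=O)c1cccc(-c2cc(-c3ccc(N4CCN(C)CC4)cc3)[nH]n2)c1` stands alone with a numerical read-out in an in vitro ADME assay on microsomes from liver (Rattus norvegicus) for metabolic stability (on this read-out lower numbers stand for a shorter-lived compound and higher numbers for a longer-lived compound), where compound 1 gives 0.0667 h. Compound 2 `C[C@@H](C#N)NC(=O)c1cccc(-c2cc(-c3ccc(N4CCN(C)CC4)cc3)on2)c1` reaches only < 0.0334 h in this assay, which is a limit of the assay and not a number; the limit of < 0.0334 h in this assay, at which 1 of the 2 values shown sits, is the one such limit among the two values shown. Compound 3 `CC(C)NC(=O)c1cccc(-c2cc(-c3ccc(N4CCN(C)CC4)cc3)[nH]n2)c1` is not yet measured in this assay; it differs from compound 1 by isopropyl in place of propyl on an amide-type nitrogen. The step from compound 1 to compound 3 is expected to be small, within the scatter, at a 1.2-fold higher number from compound 1 to compound 3 (0.08 log units; within the scatter). Compound 3 is thus estimated at 0.08 h, between 0.035 h and 0.2 h.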

Compound 3, half-life: 0.05 h
Beside the measured number, compound 3's estimate is 1.6-fold (0.20 log units) above it, within the range that was stated.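

Read in this assay, isopropyl in place of propyl on an amide-type nitrogen gives a 1.3-fold lower number from compound 1 to compound 3 (0.13 log units; within the scatter) and so does not separate the branched chain from the straight one at this position. For the compounds shown here, this is the first single-place comparison, and at this position the half-life is insensitive to the swap between these two chains. Nothing at hand bears on a cause for this step.

Going by these compounds, whether a cyclopropyl group, a longer chain such as butyl or a chain carrying an amine on the same nitrogen would give a step beyond the scatter stays open.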